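This account rests on a few compounds, and the source may have more. Where it says the series, first, only, none or still open, it means among the compounds named here.

Measured compounds:
Compound 1, `N#CC1=C(N)Oc2c(c3nc4ccccc4nc3c3ccccc23)C12C(=O)N(Cc1cnnn1-c1ccc(F)cc1)c1ccccc12`, in a functional assay on HepG2 cells (Homo sapiens) for antiproliferative activity, read by MTT assay, with a stated time of 48 h (on this read-out lower numbers stand for stronger inhibition and higher numbers for weaker inhibition), gives > 50000 nM, which is a limit of the assay and not a number.
Compound 2, `N#CC1=C(N)Oc2c(c3nc4ccccc4nc3c3ccccc23)C12C(=O)N(Cc1cnnn1-c1cccc(Br)c1)c1ccccc12`, in this assay gives > 50000 nM, again a limit of the assay.

Among the compounds with values here, compound 2 therefore stands at the limit of this assay, and the limit of > 50000 nM in this assay, at which 2 of the 2 values shown sit, shows that every value so far sits at that same limit. Within the data shown here, the only step among the measured compounds, a step that the two limits leave unreadable from compound 1 to compound 2, has no readable size, because both of its ends are limits. Compound 3, `CCOc1ccccc1-n1nncc1CN1C(=O)C2(C(C#N)=C(N)Oc3c2c2nc4ccccc4nc2c2ccccc32)c2ccccc21`, differs from compound 2 in one place: 2-ethoxyphenyl in place of 3-bromophenyl on an aromatic nitrogen. Among the measured compounds shown here, no measured step bears on this change with a readable size; the one step available left the read-out at the limit at both ends. For the measured compounds named here, one therefore expects no step in this assay that can be read beyond the scatter, and a result that most likely is again a limit. The estimate for compound 3 is 60000 nM, within 20000 nM to 200000 nM. The step this estimate implies, a step that the limit leaves unreadable from compound 2 to compound 3, is expected to stay within the scatter.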

Compound 3, half-maximal inhibitory concentration: > 50000 nM
Compound 3: a limit, no number; the forecaster's own chance of this, stated with the estimate: 85%; the middle value is on the limit's open side.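

In this assay compound 3 gives > 50000 nM, a limit of the assay and not a number. Neither its step from compound 1 nor its step from compound 2 can be read, and all three compounds sit together: the limit of > 50000 nM in this assay, at which 3 of the 3 values shown sit.

The compounds shown leave open how far any group on this aromatic nitrogen moves the read-out in this assay: none of them gives a number.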